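The source may report more compounds than this note shows. Statements on the series, on what has been measured and on what is new or still open speak of the compounds shown alone.

Measured in an ADME assay on microsomes from liver (Homo sapiens) for metabolic stability, with a stated time of 10 min; a higher number here means that more of the compound is left, a lower number that less of the compound is left:
compound 1 `Cc1cccc(C)c1COC(c1ccc([C@]2(S(=O)(=O)c3ccc(F)cc3)CCN(C(=O)[C@H]3CC[C@H](C(=O)O)CC3)C2)cc1)(C(F)(F)F)C(F)(F)F`: 89%
compound 2 `COc1cccc(F)c1COC(c1ccc([C@]2(S(=O)(=O)c3ccc(F)cc3)CCN(C(=O)[C@H]3CC[C@H](C(=O)O)CC3)C2)cc1)(C(F)(F)F)C(F)(F)F`: 82%
compound 3 `O=C(O)[C@H]1CC[C@H](C(=O)N2CC[C@](c3ccc(C(OCC4CC4)(C(F)(F)F)C(F)(F)F)cc3)(S(=O)(=O)c3ccc(F)cc3)C2)CC1`: 75%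

In this assay compound 3 stands at 75%. The measured steps that reach it run a number 7 percentage points lower from compound 2 to compound 3 (within the scatter) and a number 14 percentage points lower from compound 1 to compound 3 (beyond the scatter). The next analogue is compound 4 `O=C(O)[C@H]1CC[C@H](C(=O)N2CC[C@](c3ccc(C(OCC4CCCC4)(C(F)(F)F)C(F)(F)F)cc3)(S(=O)(=O)c3ccc(F)cc3)C2)CC1`, with this change: cyclopentyl in place of cyclopropyl on a saturated chain carbon bound to an oxygen on a saturated carbon. It has cyclopentyl in place of cyclopropyl on a saturated chain carbon bound to an oxygen on a saturated carbon. Those two steps bear on it only through the shared place, since neither goes from cyclopropyl to cyclopentyl. No change beyond the scatter is therefore expected in this assay, with only a slight downward lean. The estimated step is a number 3 percentage points lower from compound 3 to compound 4 (within the scatter). The expected value for compound 4 is 72%, within an estimated range of 58% to 86%.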

Compound 4, percent of the compound remaining: 73%
Compound 4: the middle estimate sits 1 percentage points below what was measured; the measured number falls inside the stated range.
By their numbers in this assay, from the lowest: compounds 4, 3, 2 and 1 (each within the scatter of the next, the first and the last beyond it).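

In this assay, cyclopentyl in place of cyclopropyl at this place gives a number 2 percentage points lower from compound 3 to compound 4 (within the scatter), so the larger saturated ring leaves the number within the scatter of the smaller one. Against the two aromatic groups, cyclopentyl gives a number 9 percentage points lower from compound 2 to compound 4 (within the scatter) and a number 16 percentage points lower from compound 1 to compound 4 (beyond the scatter), so only the step from 2,6-dimethylphenyl lies beyond the scatter, as it did for cyclopropyl. Nothing given here explains these numbers. The compounds shown leave open how an open alkyl chain, a cyclohexyl ring or a saturated ring carrying an amine would read at this place.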